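This account rests on a few compounds, and the source may have more. Where it says the series, first, only, none or still open, it means among the compounds named here.

Measured so far in an in vitro functional assay on cells (Fibroblast) for agonist activity at Alpha-1A adrenergic receptor (Homo sapiens); a lower number here means that less compound is needed, a higher number that more compound is needed for the effect:
compound 1, `Cn1ncnc1-c1ccccc1NCC1=NCCN1`: 2 nM
compound 2, `Cn1nccc1-c1ccccc1NCC1=NCCN1`: 10 nM
compound 3, `c1ccc(-c2cn[nH]c2)c(NCC2=NCCN2)c1`: 1.26 nM

Compound 3 has the lowest of the three numbers, but its separation from compound 1 is within the scatter (a 1.6-fold lower number from compound 1 to compound 3 (0.20 log units; within the scatter)), so the two cannot be ordered; only compound 2 stands apart from compound 3, by a 7.9-fold lower number from compound 2 to compound 3 (0.90 log units; beyond the scatter).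

Compound 4, `Cn1cccc1-c1ccccc1NCC1=NCCN1`, is not yet measured. It differs from compound 3 in one place: 1-methyl-1H-pyrrol-2-yl in place of 1H-pyrazol-4-yl on an aromatic carbon. Within the data shown here, two measured steps bear on this. Going from a ring with a hydrogen-bond donor to a methylated ring with none gave a 7.9-fold lower number from compound 2 to compound 3 (0.90 log units; beyond the scatter) read in reverse; dropping one ring nitrogen among methylated rings gave a 5.0-fold higher number from compound 1 to compound 2 (0.70 log units; beyond the scatter). The change to compound 4 combines both directions, so a higher number beyond the scatter is expected, roughly a 12-fold higher number from compound 3 to compound 4 (1.08 log units; beyond the scatter). Compound 4 is therefore estimated at 15 nM, with a range of 4 nM to 60 nM.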

Compound 4, half-maximal effective concentration: 20 nM
Compound 4: the middle estimate sits 1.3-fold (0.12 log units) below what was measured; low and high end bracket the measured number.
By their numbers in this assay, from the lowest: compounds 3 and 1 (each within the scatter of the next); then compounds 2 and 4 (each within the scatter of the next).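

In this assay, replacing the 1H-pyrazol-4-yl group with 1-methyl-1H-pyrrol-2-yl on this aromatic carbon gives the largest step in the series, a 16-fold higher number from compound 3 to compound 4 (1.20 log units; beyond the scatter), so this position does not accept every five-membered aromatic ring equally. The number of ring hetero atoms does not track the result in a simple way among the methylated rings: 1-methyl-1H-1,2,4-triazol-5-yl stands apart, with a 10-fold higher number from compound 1 to compound 4 (1.00 log units; beyond the scatter), whereas the pyrazole and pyrrole rings cannot be ordered, with a 2.0-fold higher number from compound 2 to compound 4 (0.30 log units; within the scatter). No measurement here gives a reason for these steps.

On these data alone, what the methyl group contributes alone remains open, as the unmethylated 1H-pyrazol-4-yl group also differs from the others in its point of attachment. Also open, as far as these compounds go, is how a phenyl ring, a carboxylic acid or an aminomethyl chain would behave on this carbon.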